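The source may hold more compounds than are shown below. What is called first, only, known or untested is meant among the compounds shown, and "the series" means these compounds.

Measured compounds in this series:

compound 1, `CNC(=O)c1cc(C(=O)NC2CC2)cn(Cc2nccc3[nH]ccc23)c1=O` — 1.7
compound 2, `CNC(=O)c1cc(C(=O)NC2CCC2)cn(Cc2ccccn2)c1=O` — 2.2
compound 3, `CNC(=O)c1cc(C(=O)NC2CCC2)cn(Cc2cccnc2)c1=O` — 1.8

All three numbers come from a physicochemical assay for lipophilicity, at pH 7.4; a higher number here means a more lipophilic compound, a lower number a more polar compound. Compound 1 gives the lowest of the three values, although compound 3 sits within the scatter of it, so no order between compound 1 and compound 3 can be read; compound 2 lies clearly higher than compound 1. Within the data shown here, the only step between compounds differing in one place is a number 0.40 log units lower from compound 2 to compound 3 (beyond the scatter), a modest change for exchanging one pyridinyl isomer for another at the saturated chain carbon bound to the aromatic nitrogen.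

Compound 4, `CNC(=O)c1cc(C(=O)NC2CC2)cn(Cc2cccc(C#N)c2)c1=O`, has not yet been measured in this assay. Against compound 1 the change is a group of 8 heavy atoms (7 carbon, 1 nitrogen; one six-membered aromatic ring of carbon only) in place of a group of 9 heavy atoms (7 carbon, 2 nitrogen; one five-membered aromatic ring with 1 hetero atom, one six-membered aromatic ring with 1 hetero atom), on a saturated chain carbon bound to an aromatic nitrogen. Among the measured compounds shown here, no measured step mirrors this exchange; the step from compound 2 to compound 3 is at the same place but swaps far more similar groups, and its size is the only guide to how sensitive this position is. For compound 4 a modest upward step, a number 0.60 log units higher from compound 1 to compound 4 (beyond the scatter), is expected, beyond the scatter but not far beyond it. Compound 4 is therefore estimated at 2.3, within a range from 1.8 to 2.8.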

Compound 4, distribution coefficient: 2.6
The estimate for compound 4 lay 0.30 log units below the measured number, within the range that was stated.
By their numbers in this assay, from the lowest: compounds 1 and 3 (each within the scatter of the next); then compound 2; then compound 4.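

At the saturated chain carbon bound to an aromatic nitrogen, this assay moves further with 3-cyanophenyl in place of the two-ring group, a number 0.90 log units higher from compound 1 to compound 4 (beyond the scatter), than with the swap between pyridine isomers, a number 0.40 log units lower from compound 2 to compound 3 (beyond the scatter). Among these compounds, the position can therefore carry a wider range of values than the earlier compounds showed, and a group with no ring nitrogen and no hydrogen-bond donor sits at the upper end of the series so far. This single exchange alters ring count, nitrogen count and donor count together, and no data on the compounds explain the size of the step.

Open, going by these compounds, is how much of the step belongs to the nitrile itself: a pair with an unsubstituted phenyl at this place would separate it from the ring change. Also open, on these data alone, is how a charged group, such as an amine or a carboxylic acid, would read here.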